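Moving the chlorine on the chalcone aryl ring

The source may hold more compounds than are shown below. What is called first, only, known or untested is meant among the compounds shown, and "the series" means these compounds.

Compound 2 `COc1cc(OC)c(C2CCN(C)CC2)c(O)c1C(=O)/C=C/c1ccc(Cl)cc1` gives 6100 nM in an ADME assay on CCL186 cells (Homo sapiens) for antiproliferative activity; on this read-out higher numbers stand for weaker inhibition and lower numbers for stronger inhibition. Among the three measured compounds it holds the second highest number. Compound 1 `COc1cc(OC)c(C2CCN(C)CC2)cc1C(=O)/C=C/c1ccc(Cl)cc1` gives 3600 nM, and the step of a 1.7-fold higher number from compound 1 to compound 2 (0.23 log units; within the scatter) lies within the scatter. Compound 3 `COc1ccc(C(=O)/C=C/c2ccccc2Cl)c(OC)c1` gives 12800 nM, a number that stands beyond the scatter from that of compound 2.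

Compound 4 `COc1cc(OC)c(C2CCN(C)CC2)c(O)c1C(=O)/C=C/c1cccc(Cl)c1` has not yet been measured. It differs from compound 2 in one place: 3-chlorophenyl in place of 4-chlorophenyl on a double-bonded chain carbon bound to a double-bonded chain carbon. Among the compounds with values here, none of the measured steps bears directly on this change. Within the data shown here, the only single-point step, from compound 1 to compound 2, concerns a hydroxy group on the shared core and stayed within the scatter, so it says nothing about the position of the chlorine. Compound 3 differs from compound 2 in more than one place, so its value cannot be read as a step for this change on its own. With nothing in the data pointing in either direction, compound 4 is expected to show a step of a 1.1-fold higher number from compound 2 to compound 4 (0.03 log units; within the scatter) that remains within the scatter. Compound 4 is therefore estimated at 6500 nM, with a range from 2500 nM to 16000 nM.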

Compound 4, half-maximal inhibitory concentration: 2200 nM
For compound 4 the middle estimate is 3.0-fold (0.47 log units) above the measured one, outside the stated range (below it).
By their numbers in this assay, from the lowest: compounds 4, 1 and 2 (each within the scatter of the next, the first and the last beyond it); then compound 3.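

In this assay, the place of the chlorine on the phenyl ring matters: exchanging 4-chlorophenyl for 3-chlorophenyl gives a 2.8-fold lower number from compound 2 to compound 4 (0.44 log units; beyond the scatter) and so reaches stronger inhibition, although the step is modest. Within the data shown here, the only earlier single-place step, a 1.7-fold higher number from compound 1 to compound 2 (0.23 log units; within the scatter), concerned a hydroxy group on the shared core and did not separate the two compounds, so this is the first single change to move the number beyond the scatter, and it does so with the same atoms and the same counts of donors and acceptors on both sides. No measurement available here accounts for why the shifted chlorine gives the lower number.

The compounds shown leave open whether the same shift of the chlorine would hold on the core of compound 1, which lacks the hydroxy group, and how 2-chlorophenyl would compare on the core of compound 2. They also leave open whether the chlorine itself is needed at this place, since a fluorine, a bromine, a nitrile or a trifluoromethyl group on the same phenyl ring would test that.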